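This account rests on a few compounds, and the source may have more. Where it says the series, first, only, none or still open, it means among the compounds named here.

Of the compounds shown here, three sharing one core have been read in a physicochemical assay for solubility, read by nephelometry; on this read-out higher numbers stand for higher solubility and lower numbers for lower solubility. In this assay compound 1 `CC1(C)C(=O)N(c2ccc(SC(F)(F)F)cc2)C(=O)N1Cc1ccnc(N2CCNCC2)c1` gives < 0.024 ug/mL, which is a limit. Compound 2 `CN(C)c1cc(CN2C(=O)N(c3ccc(SC(F)(F)F)cc3)C(=O)C2(C)C)ccn1` gives < 0.022 ug/mL, also a limit. Compound 3 `CC1(C)C(=O)N(c2ccc(SC(F)(F)F)cc2)C(=O)N1Cc1ccnc(Nc2ccccc2)c1` gives < 0.025 ug/mL, again a limit, and so it has no numerical place in the series, as the other two values are limits as well.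

Compound 4 `CC(C)Nc1cc(CN2C(=O)N(c3ccc(SC(F)(F)F)cc3)C(=O)C2(C)C)ccn1` differs from compound 3 by one change: isopropyl in place of phenyl on a nitrogen on an aromatic ring. In words, this is isopropyl in place of phenyl on a nitrogen on an aromatic ring, or anilino to isopropylamino.

Among the measured compounds shown here, three measured steps bear on this change: a step that the two limits leave unreadable from compound 1 to compound 2, a step that the two limits leave unreadable from compound 1 to compound 3 and a step that the two limits leave unreadable from compound 2 to compound 3. None of them gives a size to carry over. The expectation for compound 4 rests on compound 3 at < 0.025 ug/mL, a limit, and a limit is the likely report for compound 4 too. The estimated step is a number no lower from compound 3 to compound 4 (the limit leaves the size open), with nothing expected beyond the scatter in either direction. The estimate for compound 4 is 0.025 ug/mL, with an expected range of 0.01 ug/mL to 0.08 ug/mL.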

Compound 4, solubility: < 0.023 ug/mL
Compound 4 gave a limit, no number; the forecaster's own chance of this, stated with the estimate: 80%; middle value at least 1.0-fold (0.03 log units) away from the limit.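

In this assay, among the compounds shown here, compound 1, compound 2, compound 3 and compound 4 all give limits, and no step from any of them to compound 4 can be read. The compounds shown leave open where the four actual values lie relative to one another.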